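Working notes: 2-methylphenyl to 2-chlorophenyl

A few compounds are considered here, and "the series" means these few. Any claim that something is new, unique, unknown or untested is made for them only; others in the source may bear on it.

Measured so far in a functional assay on LN-229 cells (Homo sapiens) for antiproliferative activity, with a stated time of 72 h; on this read-out lower numbers stand for stronger inhibition and higher numbers for weaker inhibition
- compound 1 `Nc1ncnn2c([C@@H]3O[C@H](CO)[C@@H](O)[C@H]3O)cc(C#Cc3cccs3)c12` gives > 100000 nM (a limit)
- compound 2 `Cc1ccccc1-c1cc([C@@H]2O[C@H](CO)[C@@H](O)[C@H]2O)n2ncnc(N)c12` gives > 100000 nM (a limit)

Compound 2 stands at > 100000 nM and this is a limit, not a number. Compound 3 `Nc1ncnn2c([C@@H]3O[C@H](CO)[C@@H](O)[C@H]3O)cc(-c3ccccc3Cl)c12` carries chloro in place of methyl on an aromatic carbon, and chloro in place of methyl on an aromatic carbon is the whole difference from compound 2. Among the compounds with values here, the one measured step that bears on this is a step that the two limits leave unreadable from compound 1 to compound 2 and it gives no size to carry forward. Within the data shown here, the series so far offers only the limit of > 100000 nM in this assay, at which 2 of the 2 values shown sit, as its evidence. With no measured number in the series, no step beyond the scatter is expected in this assay for this exchange. The expected move is a number no higher from compound 2 to compound 3 (the limit leaves the size open) and it remains an estimate. For compound 3 the estimated value is 100000 nM with an expected range of 30000 nM to 300000 nM and a report as a limit is the likeliest outcome.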

Compound 3, half-maximal inhibitory concentration: > 100000 nM
Compound 3: a limit, no number; the forecaster's own chance of this, stated with the estimate: 85%; the middle value lies on the limit itself.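

No step can be read from compound 2 to compound 3 or from compound 1 to compound 3, as each pair offers only limits: the limit of > 100000 nM in this assay, at which 3 of the 3 values shown sit.

The compounds shown leave open how methyl and chloro compare, and whether any group on this aromatic carbon gives a measurable value.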